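Ring-nitrogen methylation across two cores: tolerated concentration

The compounds below may be only part of what the source reports. "The series", "measured", "known", "first", "only" and "open" are said of these compounds alone.

Compound 1 `c1ccc2c(c1)ccn2-c1nc(N2CCNCC2)nc2ccccc12` and compound 2 `CN1CCN(c2nc(-n3ccc4ccccc43)c3ccccc3n2)CC1` share one core; compound 3 `Cn1cc(-c2nc(N3CCNCC3)nc3ccccc23)c2ccccc21` and the not yet measured compound 4 `CN1CCN(c2nc(-c3cn(C)c4ccccc34)c3ccccc3n2)CC1` share another. The difference between the two cores is not broken down here. In an ADME assay on J774.A1 cells (Mus musculus) for cytotoxicity (a lower number here means that less compound is tolerated, a higher number that more compound is tolerated), compound 1 gives 3.11 ug/mL, compound 2 gives 7.27 ug/mL, and compound 3 gives 16 ug/mL, the highest number of the three measured, with its steps to the other two beyond the scatter.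

Within the first pair the change methyl in place of hydrogen on an amine nitrogen in a ring produced a 2.3-fold higher number from compound 1 to compound 2 (0.37 log units; beyond the scatter). Compound 4 carries the change methyl in place of hydrogen on an amine nitrogen in a ring on its own core. The surroundings of the changed position are described in the same words for both pairs, so the change is taken as the same one, made on a different core.

Within the data shown here, for compound 4 the step in this assay is expected to be a 2.2-fold higher number from compound 3 to compound 4 (0.34 log units; beyond the scatter), because a 2.3-fold higher number from compound 1 to compound 2 (0.37 log units; beyond the scatter) is the only measured instance of this change and nothing here argues for a different size on the second core. Compound 4 is therefore estimated at 35 ug/mL, with a likely range from 16 ug/mL to 80 ug/mL.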

Compound 4, half-maximal cytotoxic concentration: 1.03 ug/mL
The estimate for compound 4 lay 34-fold (1.53 log units) above the measured number, outside the stated range (below it).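

In this assay the change from piperazin-1-yl to 4-methylpiperazin-1-yl gave a 16-fold lower number from compound 3 to compound 4 (1.19 log units; beyond the scatter), so on this core less compound is tolerated after methylation, the opposite direction to that seen on the core of compound 1. In this series, neither the size nor the direction of the step carried over from one core to the other: the same change on two cores in this assay, a 2.3-fold higher number (0.37 log units; beyond the scatter) from compound 1 to compound 2 and a 16-fold lower number (1.19 log units; beyond the scatter) from compound 3 to compound 4, 36-fold (1.56 log units) apart, beyond the scatter of two such steps

This rests on a single pair per core, so it shows that the step depends on the core for these four compounds, but it gives no general rule for the series and does not show which feature of the cores is responsible.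

The compounds shown leave open which part of the difference between the two cores goes with the change of direction. They also leave open whether an ethyl group or a longer chain on the same amine nitrogen would follow the methyl step on each core.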